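This account rests on a few compounds, and the source may have more. Where it says the series, first, only, none or still open, it means among the compounds named here.

Two compounds of this series have a number in a functional assay on the whole organism (strain Wistar albino) for inhibition, with Rattus norvegicus as the target, read by paw edema, with a stated time of 2 h, at a dose of 25 mg/kg by the oral route; a lower number here means less inhibition, a higher number more inhibition at the dose given (going by the name of the read-out). Compound 1 `Cc1ccc(Nc2nn(-c3ccc(S(N)(=O)=O)cc3)c3nc(Nc4ccccc4)n(-c4ccccc4)c(=O)c23)cc1` gives 63.4% there. Compound 2 `O=c1c2c(Nc3ccc(Cl)cc3)nn(-c3ccccc3)c2nc(Nc2ccccc2)n1-c1ccccc1` gives 44% in this assay, the lower of the two numbers, and the gap to compound 1 lies beyond the scatter. For the measured compounds named here, compounds 1 and 2 differ in more than one place, so no single step between measured compounds is available.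

Compound 3 `NS(=O)(=O)c1ccc(-n2nc(Nc3ccc(Cl)cc3)c3c(=O)n(-c4ccccc4)c(Nc4ccccc4)nc32)cc1` is still to be measured in this assay. It differs from compound 2 in one place: sulfamoyl in place of hydrogen on an aromatic carbon. Cut one bond further out, the change reads phenyl to 4-sulfamoylphenyl, and compound 1, the compound with the higher number here, also carries a 4-sulfamoylphenyl.

Given that compound 1 gives 63.4% against compound 2 with 44%, the step from compound 2 to compound 3 is expected to be an increase, estimated at a number 13 percentage points higher from compound 2 to compound 3 (beyond the scatter), beyond the scatter. For compound 3 in this assay the expected value is 57%, within a range of 45% to 69%.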

Compound 3, a percentage reported as inhibition, in the whole organism at one dose (the size of the read-out at that dose, not a potency): 56.3%
The estimate for compound 3 lay 0.7 percentage points above the measured number; the measured number falls inside the stated range.
By their numbers in this assay, from the lowest: compound 2; then compounds 3 and 1 (each within the scatter of the next).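

In this assay, the change from phenyl to 4-sulfamoylphenyl can now be read in one place: sulfamoyl in place of hydrogen on an aromatic carbon gives a number 12.3 percentage points higher from compound 2 to compound 3 (beyond the scatter) for this pair. Compound 1 could not show this, as it differs from compound 2 in more than one place. With the 4-sulfamoylphenyl held constant, chloro in place of methyl on an aromatic carbon gives a number 7.1 percentage points lower from compound 1 to compound 3 (within the scatter) and so does not separate the two compounds in this assay.

Nothing at hand gives a reason for either step.

From the compounds shown here alone, whether a carboxylic acid or a methylsulfonyl group at the same place would give a step of similar size stays open. Also open, going by these compounds, is whether the sulfamoyl step holds at other doses and times.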